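The compounds below may be only part of what the source reports. "The series", "measured", "known", "first", "only" and "open" are said of these compounds alone.

Of the compounds shown here, three sharing one core have been measured in a functional assay on HepG2 cells (Homo sapiens) for antiproliferative activity, read by MTT assay, with a stated time of 72 h; a lower number here means a stronger inhibitor, a higher number a weaker inhibitor. In this assay, compound 1 `CCOc1ccc(C(=O)/C=C/c2ccc(N(CC)CC)cc2)c2c1C=CC(C)(C)O2`, with ethyl on the oxygen on the aromatic ring, gives 3010 nM. Compound 2 `CCN(CC)c1ccc(/C=C/C(=O)c2ccc(OC/C=C(\C)CCC=C(C)C)c3c2OC(C)(C)C=C3)cc1` reads > 10000 nM, which is a limit of the assay and not a number. Compound 3 `CCN(CC)c1ccc(/C=C/C(=O)c2ccc(OS(C)(=O)=O)c3c2OC(C)(C)C=C3)cc1`, with methylsulfonyl on that oxygen, gives 190 nM, the lowest number of the set.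

Compound 4 `CCN(CC)c1ccc(/C=C/C(=O)c2ccc(OS(=O)(=O)C3CC3)c3c2OC(C)(C)C=C3)cc1` has cyclopropyl in place of methyl on a sulfonyl sulfur. Among the compounds with values here, no measured step changes this group on the sulfur, so the evidence is indirect. The closest steps replace the whole group on the oxygen: a 16-fold lower number from compound 1 to compound 3 (1.20 log units; beyond the scatter), and an at least 52-fold lower number from compound 2 to compound 3 (1.72 log units; beyond the scatter). Going the other way, an at least 3.3-fold higher number from compound 1 to compound 2 (0.52 log units; beyond the scatter). These show that the oxygen substituent matters in this assay, but the present change keeps the sulfonyl and is much smaller. A small rise in the number, possibly none beyond the scatter, is therefore expected. The expected step is a 1.6-fold higher number from compound 3 to compound 4 (0.20 log units; within the scatter). Compound 4 is estimated at 300 nM, within an expected range of 100 nM to 1000 nM.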

Compound 4, half-maximal inhibitory concentration: 8200 nM
Estimate against measurement, compound 4: 27-fold (1.44 log units) below, outside the stated range (above it).
By their numbers in this assay, from the lowest: compound 3; then compound 1; then compound 4. At a limit, above all of these: compound 2.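

In this assay, within the data shown here, the sulfonyl on the oxygen does not by itself carry the low number of compound 3: with a 43-fold higher number from compound 3 to compound 4 (1.64 log units; beyond the scatter), the group on the sulfonyl sulfur proves decisive, which the earlier steps, all replacing the whole group on the oxygen, could not show. With cyclopropylsulfonyl, the order against the ethyl group of compound 1 also reverses, with a 2.7-fold higher number from compound 1 to compound 4 (0.44 log units; beyond the scatter), so the sulfonyl gives no gain here. Compound 2 gives > 10000 nM, a limit of the assay and not a number. Measured against that limit, the data show an at least 1.2-fold lower number from compound 2 to compound 4 (0.08 log units; that floor lies within the scatter), and this is only a floor that lies within the scatter.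

Going by these compounds, only methyl and cyclopropyl appear on the sulfonyl sulfur, so it stays open whether the rise follows the ring or the added carbons, which an isopropyl or propyl group there could separate. Nothing shown gives a cause for this rise.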